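Isopropyl in Place of Propyl on a Small Amide

The compounds below may be only part of what the source reports. "The series", "measured", "known", "first", "only" and "open" are said of these compounds alone.

The study holds two measured compounds and one that awaits measurement. Compound 1 `CCCC(C(N)=O)C(C)CC` gives 49 mg/kg in a functional assay on the whole organism (Spinal nerve) with Rattus norvegicus as the target (on this read-out higher numbers stand for an effect only at larger amounts of compound and lower numbers for an effect already at smaller amounts), and compound 2 `CCCC(C(N)=O)C(C)C` gives 42 mg/kg in this assay. Within the data shown here, the one measured step between them, a 1.2-fold lower number from compound 1 to compound 2 (0.07 log units; within the scatter), came from hydrogen in place of methyl on a saturated chain carbon, three bonds along the chain from a carbonyl carbon. Compound 2 thus carries the lowest of the two numbers, its nearest neighbour compound 1 sitting at a gap that lies within the scatter.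

Compound 3 `CC(C)C(C(N)=O)C(C)C` differs from compound 2 by isopropyl in place of propyl on a saturated chain carbon bound to a carbonyl carbon and a saturated chain carbon. Among the measured compounds shown here, no measured step replaces propyl with isopropyl; the only step known, a 1.2-fold lower number from compound 1 to compound 2 (0.07 log units; within the scatter), shortened a chain and stayed within the scatter. Compound 3 is therefore expected to sit close to compound 2, with a step of a 1.1-fold lower number from compound 2 to compound 3 (0.02 log units; within the scatter) in this assay that is not expected to go beyond the scatter in either direction. Compound 3 is estimated at 40 mg/kg, with a range from 20 mg/kg to 80 mg/kg.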

Compound 3, dose for half-maximal effect: 58 mg/kg
The estimate for compound 3 lay 1.5-fold (0.16 log units) below the measured number; measured number inside the range.
By their numbers in this assay, from the lowest: compounds 2, 1 and 3 (each within the scatter of the next).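

At the saturated chain carbon bound to a carbonyl carbon and a saturated chain carbon, the compounds shown gain their only measured change in this assay: isopropyl in place of propyl gives a 1.4-fold higher number from compound 2 to compound 3 (0.14 log units; within the scatter). Propyl and isopropyl hold the same atoms joined differently, so this step shows that a rearrangement of the group at this place leaves the number within the scatter, as hydrogen in place of methyl did in the other step, a 1.2-fold lower number from compound 1 to compound 2 (0.07 log units; within the scatter). No independent measurement bears on why this step is so small.

The compounds shown leave open whether any group at this place can move the number beyond the scatter, since propyl and isopropyl are the only two groups compared there. As far as these compounds go, a longer chain such as hexyl, a cyclohexyl ring, or an amine or a carboxylic acid in the same place would test this, and the amide itself stays unchanged throughout, so the effect of a change to it also remains unknown.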